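Ring Contraction on the Amide of a Diazabicyclic Core

The compounds below may be only part of what the source reports. "The series", "measured", "known", "first", "only" and "open" are said of these compounds alone.

Measured compounds:
compound 1, `O=C(C1CCC1)N1CC2CC(C1)N2`: 2900 nM
compound 2, `O=C(C1CCCC1)N1CC2CC(C1)N2`: 11000 nM

Going by the values given here, in an assay on SH-EP1 cells for agonist activity at Neuronal acetylcholine receptor; alpha4/beta2 (Homo sapiens), read by FLIPR and calcium flux (a lower number here means that less compound is needed, a higher number that more compound is needed for the effect), compound 1 gives 2900 nM, the lowest of the two numbers known so far. Its nearest neighbour is compound 2, which in this assay gives 11000 nM, a higher number that lies beyond the usual scatter. The two differ only in the carbocycle on the carbonyl carbon, and the smaller ring of compound 1 goes with the lower number.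

Compound 3, `C[C@@H]1C[C@@H]1C(=O)N1CC2CC(C1)N2`, has not been measured in this assay. It differs from compound 1 by a group of 4 heavy atoms (4 carbon; one three-membered non-aromatic ring of carbon only) in place of a group of 4 heavy atoms (4 carbon; one four-membered non-aromatic ring of carbon only), on a carbonyl carbon. The atom count is unchanged, and the carbocycle is again reduced by one ring member, with two defined stereocentres added. Among the compounds with values here, no measured pair shows this exact change, so the step is estimated, not known: compound 3 is expected to give 2500 nM, within 800 nM to 8000 nM, a step of a 1.2-fold lower number from compound 1 to compound 3 (0.06 log units; within the scatter) that is expected to stay close to compound 1.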

Compound 3, half-maximal effective concentration: 2100 nM
Beside the measured number, compound 3's estimate is 1.2-fold (0.08 log units) above it, within the range that was stated.
By their numbers in this assay, from the lowest: compounds 3 and 1 (each within the scatter of the next); then compound 2.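

In this assay, replacing cyclobutyl with the three-membered carbocycle of compound 3, on a carbonyl carbon whose other neighbours are an amide-type nitrogen in a ring, gives a 1.4-fold lower number from compound 1 to compound 3 (0.14 log units; within the scatter). The earlier pair had shown only that the carbocycle on this carbonyl carbon can change the number, whereas this step shows that a different ring size with the same atom count, carrying two defined stereocentres, can leave the number indistinguishable from that of compound 1. No available evidence bears on why the two numbers stay so close. As far as these compounds go, whether the mirror-image form of compound 3 would give a similar number remains open. So does the outcome in this assay of placing an amine, a carboxylic acid or a longer chain on this carbonyl carbon.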